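Benzyl variation at the aromatic nitrogen in the series

This account rests on a few compounds, and the source may have more. Where it says the series, first, only, none or still open, it means among the compounds named here.

Measured so far:
compound 1, `Cc1ccc(Cn2cc(COc3ccc4c(=O)ccoc4c3)nn2)cc1`, gives > 100000 nM in a functional assay on SGC-7901 cells (Homo sapiens) for cytotoxicity, read by MTT assay, with a stated time of 48 h (on this read-out higher numbers stand for weaker inhibition and lower numbers for stronger inhibition), a limit of the assay.
compound 2, `O=c1ccoc2cc(OCc3cn(Cc4cccc(Br)c4)nn3)ccc12`, gives > 100000 nM in this assay, a limit of the assay.

Compound 1 stands at the limit: both values shown sit at the limit of > 100000 nM in this assay, at which 2 of the 2 values shown sit, so no number places it. Within the data shown here, the one measured step, a step that the two limits leave unreadable from compound 1 to compound 2, is therefore unreadable in size and direction. Compound 3, `O=c1ccoc2cc(OCc3cn(Cc4ccc(Cl)cc4Cl)nn3)ccc12`, differs from compound 1 by 2,4-dichlorophenyl in place of 4-methylphenyl on a saturated chain carbon bound to an aromatic nitrogen. Among the measured compounds shown here, no measured step bears on this change with a readable size, and nothing in the two values shown suggests a move off the limit. Compound 3 is therefore expected to remain at the limit, with a step that the limit leaves unreadable from compound 1 to compound 3 that is estimated to lie within the scatter. For compound 3 the estimate is 150000 nM, with a range from 40000 nM to 600000 nM, and most likely reported only as a limit.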

Compound 3, half-maximal inhibitory concentration: > 100000 nM
Compound 3 ended at the assay's limit; the forecaster's own chance of this, stated with the estimate: 80%; the middle value lies beyond the limit too.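

In this assay compound 3 gives > 100000 nM, a limit of the assay, so the steps from compound 1 and compound 2 to compound 3 cannot be read: the limit of > 100000 nM in this assay, at which 3 of the 3 values shown sit.

The compounds shown leave open whether any group at this place moves the shared core off the limit, and the size and direction of every step among them.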